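From 4-Chloro-2-fluorophenyl to 1-Phenylethyl on the Ring Nitrogen

The source may report more compounds than this note shows. Statements on the series, on what has been measured and on what is new or still open speak of the compounds shown alone.

Three measured compounds share one core and differ only in the group on an amine nitrogen in a ring. In an assay on CHO cells for displacement of a labelled ligand from adenosine receptor A1 (Homo sapiens), read by scintillation counting, with a stated time of 90 min, in the presence of a further agent that is not named here (a higher number here means a weaker inhibitor, a lower number a stronger inhibitor), compound 1 `CCCn1c(=O)[nH]c2nc(-c3ccc(S(=O)(=O)N4CCN(c5ccccc5)C(C)C4)cc3)[nH]c2c1=O` gives only a limit, > 1000 nM. Compound 2 `CCCn1c(=O)[nH]c2nc(-c3ccc(S(=O)(=O)N4CCN(c5ccc(I)cc5)CC4)cc3)[nH]c2c1=O` likewise gives only a limit, > 1000 nM. Compound 3 `CCCn1c(=O)[nH]c2nc(-c3ccc(S(=O)(=O)N4CCN(c5ccc(Cl)cc5F)CC4)cc3)[nH]c2c1=O` also gives only a limit, > 1000 nM. The step that the two limits leave unreadable from compound 2 to compound 3 therefore cannot be read, and the limit of > 1000 nM in this assay, at which 3 of the 3 values shown sit, states all that is known of compound 3, which stands where every measured value sits. Compound 4 `CCCn1c(=O)[nH]c2nc(-c3ccc(S(=O)(=O)N4CCN(C(C)c5ccccc5)CC4)cc3)[nH]c2c1=O` differs from compound 3 by 1-phenylethyl in place of 4-chloro-2-fluorophenyl on an amine nitrogen in a ring. Going by the values given here, no measured step bears on this change with a readable size, so no direction can be expected beyond the scatter. Compound 4 is expected to give 3000 nM, within 700 nM to 15000 nM, a step that the limit leaves unreadable from compound 3 to compound 4 that most likely ends again as a limit.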

Compound 4, inhibition constant: >= 1000 nM
Compound 4 gave a limit, no number; the forecaster's own chance of this, stated with the estimate: 75%; the middle value does not contradict the limit.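

Compound 4, like compound 2 and compound 3, gives only a limit in this assay, so no step among these three compounds can be read. The compounds shown leave open whether the group on the amine nitrogen in a ring changes inhibitor strength at all.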